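Methoxy in place of hydrogen on the phenyl of compound 1

This account rests on a few compounds, and the source may have more. Where it says the series, first, only, none or still open, it means among the compounds named here.

Going by the values given here, compound 1 `CC(C)(C)c1ccc(Cn2nc(-c3ccccc3)cc2C(=O)NN)cc1` gives 26600 nM in a functional assay on A549 cells (Homo sapiens) for inhibition, with a stated time of 24 h (a lower number here means a stronger inhibitor, a higher number a weaker inhibitor), the lowest of the three numbers so far. Compound 3 `NNC(=O)c1cc(-c2ccc(Cl)cc2)nn1Cc1ccc(Cl)nc1` gives 30200 nM, within the scatter of compound 1, while compound 2 `NNC(=O)c1cc(-c2ccccc2)nn1Cc1ccc(Cl)nc1` gives 67700 nM, beyond it. Among the compounds with values here, the only single-point step measured is a 2.2-fold lower number from compound 2 to compound 3 (0.35 log units; beyond the scatter). Compound 4 `COc1ccc(-c2cc(C(=O)NN)n(Cc3ccc(C(C)(C)C)cc3)n2)cc1` differs from compound 1 by methoxy in place of hydrogen on an aromatic carbon. The step from compound 2 to compound 3, likewise a small group added to a phenyl ring, bears on this change, but a chloro is not a methoxy and that step was only modest; a small lowering or no change beyond the scatter is expected, a 1.3-fold lower number from compound 1 to compound 4 (0.12 log units; within the scatter). Compound 4 is therefore estimated at 20000 nM, with a range from 8000 nM to 50000 nM.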

Compound 4, half-maximal inhibitory concentration: 23900 nM
The estimate for compound 4 lay 1.2-fold (0.08 log units) below the measured number, within the range that was stated.
By their numbers in this assay, from the lowest: compounds 4, 1 and 3 (each within the scatter of the next); then compound 2.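

In this assay the change from phenyl to 4-methoxyphenyl gives a 1.1-fold lower number from compound 1 to compound 4 (0.05 log units; within the scatter) and so the core of compound 1 takes methoxy at this place with no change beyond the scatter. The chloro step on the other background, a 2.2-fold lower number from compound 2 to compound 3 (0.35 log units; beyond the scatter), lay beyond the scatter, so a group added to this phenyl does not always move the number. No measurement at hand explains the result. Open, on these data alone, is whether an amine or a carboxylic acid at this place would move the number beyond the scatter. Also open, as far as these compounds go, is how methoxy would behave on compound 2.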